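Notes on compound 3 and the step to compound 4

The source may report more compounds than this note shows. Statements on the series, on what has been measured and on what is new or still open speak of the compounds shown alone.

Measured compounds:
- compound 1 `COc1cc(C)cc(-c2c(-c3ccnc(-c4ccc(C(C)=O)cc4)c3)cnn2CC#N)c1`: in a functional assay on CAKI-1 cells (Homo sapiens) for inhibition, read by sulforhodamine B assay, with a stated time of 48 h (on this read-out lower numbers stand for stronger inhibition of growth and higher numbers for weaker inhibition of growth), compound 1 gives > 100000 nM, which is a limit of the assay and not a number (the limit of > 100000 nM in this assay, at which 1 of the 3 values shown sits).
- compound 2 `COc1cc(C)cc(-c2nn(CC#N)cc2-c2ccc(-c3cccc(C(C)=O)c3)nc2)c1`: in this assay compound 2 gives 10500 nM.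
- compound 3 `Cc1cc(O)cc(-c2nn(CC#N)cc2-c2ccnc(-c3ccc(Oc4ccccc4)cc3)c2)c1`: in this assay compound 3 gives 5780 nM.

Compound 3 holds the lowest of the two numbers shown, but its nearest neighbour, compound 2, sits within the usual scatter, so no order between the two can be claimed. For the measured compounds named here, no pair of measured compounds differs in one place, so no measured step is available to lean on.

Compound 4 `Cc1cc(O)cc(-c2nn(CC#N)cc2-c2ccnc(-c3ccc(N(C)C)cc3)c2)c1` differs from compound 3 by dimethylamino in place of phenoxy on an aromatic carbon. Going by the values given here, with no comparable step, the size and direction of the change remain open; the working expectation is a step of no more than modest size, and possibly none beyond the scatter, a 1.4-fold higher number from compound 3 to compound 4 (0.14 log units; within the scatter). Compound 4 is therefore expected to give about 8000 nM in this assay, with a range from 2500 nM to 40000 nM.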

Compound 4, concentration for total growth inhibition: 16400 nM
For compound 4 the middle estimate is 2.1-fold (0.31 log units) below the measured one; the range from low to high includes it.
By their numbers in this assay, from the lowest: compounds 3, 2 and 4 (each within the scatter of the next, the first and the last beyond it). At a limit, above all of these: compound 1.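

For the compounds shown here, this is the first step that can be read between two compounds differing in one place: in this assay, dimethylamino in place of phenoxy, on an aromatic carbon para to a large group, gives a 2.8-fold higher number from compound 3 to compound 4 (0.45 log units; beyond the scatter), a modest step. The position is therefore not indifferent to the group it carries, with phenoxy and its aromatic ring standing at the lower number and dimethylamino, with no ring, at the higher. Nothing measured here gives a reason for this step.

One pair cannot separate the loss of the ring from the change of the atom attached to the core side of the group, and compounds 1 and 2 differ from these two in more than one place. A phenylamino or a methoxy group on the same carbon would bear on that separation.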